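Trimethoxyphenyl Analogue Expected to Stay Above Limit

The source may report more compounds than this note shows. Statements on the series, on what has been measured and on what is new or still open speak of the compounds shown alone.

Compound 1, `N#Cc1c(-c2ccc(F)cc2)c(C#N)c(=O)n(/N=C/c2cn(-c3ccccc3)nc2-c2ccccc2)c1N`, in an ADME assay on HeLa cells (Homo sapiens) for cytotoxicity, read by MTT assay (a lower number here means a stronger inhibitor, a higher number a weaker inhibitor), gives > 200 ug/mL, which is a limit of the assay and not a number. Compound 2, `COc1ccc(-c2c(C#N)c(N)n(/N=C/c3cn(-c4ccccc4)nc3-c3ccccc3)c(=O)c2C#N)cc1`, in this assay gives > 200 ug/mL, again a limit rather than a number.

So compound 2 stands at the upper edge of what this assay reports, with the limit of > 200 ug/mL in this assay, at which 2 of the 2 values shown sit. For the measured compounds named here, the only measured step is a step that the two limits leave unreadable from compound 1 to compound 2, which the two limits leave unreadable. Compound 3, `COc1cc(-c2c(C#N)c(N)n(/N=C/c3cn(-c4ccccc4)nc3-c3ccccc3)c(=O)c2C#N)cc(OC)c1OC`, carries 3,4,5-trimethoxyphenyl in place of 4-methoxyphenyl on an aromatic carbon. No readable step bears on this change, so no step beyond the scatter is expected; compound 3 is estimated at 250 ug/mL, between 120 ug/mL and 600 ug/mL, and the expected step is a step that the limit leaves unreadable from compound 2 to compound 3.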

Compound 3, half-maximal inhibitory concentration: > 200 ug/mL
Compound 3 gave a limit, no number; the forecaster's own chance of this, stated with the estimate: 80%; the middle value lies beyond the limit too.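

Compound 1, compound 2 and compound 3 all sit at the same reporting limit, so no step among them can be read: the limit of > 200 ug/mL in this assay, at which 3 of the 3 values shown sit.

How far any of these compounds lies past that limit in this assay stays open, and so does whether the aromatic groups that differ among them matter at all.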